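Swapping Carboxy for Phenoxy on the Aromatic Ring

This account rests on a few compounds, and the source may have more. Where it says the series, first, only, none or still open, it means among the compounds named here.

For the measured compounds named here, in a functional assay on HeLa cells (Homo sapiens) for cytotoxicity, read by MTT assay, with a stated time of 48 h (a higher number here means a weaker inhibitor, a lower number a stronger inhibitor), compound 1 (`CC1(C)CCC[C@]2(C)[C@@H](CC[C@@](C)(O)/C=C/c3ccc(Br)cc3)[C@](C)(O)CC[C@@H]12`) gives 45900 nM and compound 2 (`CC1(C)CCC[C@]2(C)[C@@H](CC[C@@](C)(O)/C=C/c3ccc(C(=O)O)cc3)[C@](C)(O)CC[C@@H]12`) gives 45400 nM, so compound 2 stands level with its only measured neighbour. Compound 3 (`CC1(C)CCC[C@]2(C)[C@@H](CC[C@@](C)(O)/C=C/c3ccc(Oc4ccccc4)cc3)[C@](C)(O)CC[C@@H]12`) has phenoxy in place of carboxy on an aromatic carbon, para to a large group: phenoxy in place of carboxy on an aromatic carbon. Going by the values given here, one measured step bears on this change, and it replaced bromo with carboxy at the same place. That step, a 1.0-fold lower number from compound 1 to compound 2 (0.00 log units; within the scatter), lies within the scatter. Among the compounds with values here, it offers no sign that this position moves the number in this assay, but the data include no compound with a second aromatic ring at this place, so the guide is thin. The estimated change is a 1.3-fold lower number from compound 2 to compound 3 (0.10 log units; within the scatter), and no step beyond the scatter is expected. Compound 3 is estimated at 36000 nM, with an expected range from 14000 nM to 80000 nM.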

Compound 3, half-maximal inhibitory concentration: 3480 nM
Estimate against measurement, compound 3: 10-fold (1.01 log units) above; the whole stated range lies above it.
By their numbers in this assay, from the lowest: compound 3; then compounds 2 and 1 (each within the scatter of the next).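

In this assay this position turned out to be able to move the number: the earlier swap of bromo for carboxy had left it flat, whereas phenoxy gives a 13-fold lower number from compound 2 to compound 3 (1.12 log units; beyond the scatter) and, set against bromo, a 13-fold lower number from compound 1 to compound 3 (1.12 log units; beyond the scatter). Bromo and carboxy thus stay together within the scatter, and only phenoxy, the one group of the three that brings a six-membered aromatic ring of carbon only, stands apart from them. No measured evidence is at hand to account for this drop.

On these data alone, a directly attached phenyl or a benzyloxy group is not among the compounds, so it stays open whether the lower number goes with the second aromatic ring itself or with the oxygen that joins it. Also open, as far as these compounds go, is whether a methoxy or fluoro on that ring, or an amine in place of phenoxy, would move the number further.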